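The compounds below may be only part of what the source reports. "The series", "measured", "known", "first", "only" and "open" are said of these compounds alone.

Measured compounds:
compound 1 `O=C(Nc1cnn(-c2ccccc2)c1)c1cccc(NS(=O)(=O)c2ccccc2)c1`: 26800 nM
compound 2 `Cn1cc(NC(=O)c2ccc(NS(=O)(=O)c3ccccc3)cc2)cn1`: > 100000 nM

Of the compounds shown here, two have been measured in a functional assay on A549 cells (Homo sapiens) for inhibition, read by MTT assay, with a stated time of 48 h; on this read-out lower numbers stand for stronger inhibition and higher numbers for weaker inhibition. Compound 1 `O=C(Nc1cnn(-c2ccccc2)c1)c1cccc(NS(=O)(=O)c2ccccc2)c1` gives 26800 nM. Compound 2 `Cn1cc(NC(=O)c2ccc(NS(=O)(=O)c3ccccc3)cc2)cn1` sits at the limit of > 100000 nM in this assay, at which 1 of the 2 values shown sits, so its value is a limit of the assay and not a number. For the measured compounds named here, compound 1 and compound 2 differ in more than one place, so no single step can be drawn between them; the numbers show only that compound 1 yields a measured concentration while compound 2 does not.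

The step followed here leads from compound 2 to compound 3 `Cc1ccc(-n2cc(NC(=O)c3ccc(NS(=O)(=O)c4ccccc4)cc3)cn2)cc1`, which has not yet been tested in this assay. The change is 4-methylphenyl in place of methyl on an aromatic nitrogen. Going by the values given here, no measured pair shows this exchange, so its size rests on a comparison alone: compound 1, which also bears an aromatic group on an aromatic nitrogen, gives 26800 nM.

The step from compound 2 to compound 3 is therefore expected to be an at least 2.5-fold lower number from compound 2 to compound 3 (0.39 log units; beyond the scatter), toward stronger inhibition, though a result that again stays at the limit remains quite possible. Compound 3 is estimated at 40000 nM, within a range from 12000 nM to 100000 nM.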

Compound 3, half-maximal inhibitory concentration: 54700 nM
Estimate against measurement, compound 3: 1.4-fold (0.14 log units) below; the range from low to high includes it.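

In this assay, for the compounds shown here, 4-methylphenyl in place of methyl on the aromatic nitrogen of the five-membered ring is the first single change that can be read, and it takes the core of compound 2 to a measured concentration: compound 3 gives 54700 nM. The change is read as an at least 1.8-fold lower number from compound 2 to compound 3 (0.26 log units; that floor lies within the scatter), so the data fix only a smallest possible size for it and do not show how far it extends. Compound 2 holds a limit and not a number, so the true size of the step remains unknown: the limit of > 100000 nM in this assay, at which 1 of the 3 values shown sits.

Going by these compounds, what remains open is whether the six-membered aromatic ring alone goes with the measured value or whether the methyl on that ring also plays a part, a question that a cyclohexyl group or an unsubstituted phenyl on the same aromatic nitrogen of this core would help to separate. On these data alone, it is also open how a carboxylic acid or an amine in place of the methyl on the 4-methylphenyl group would read in this assay.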